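This account rests on a few compounds, and the source may have more. Where it says the series, first, only, none or still open, it means among the compounds named here.

Measured so far:
compound 1 `CN(C)c1ccc(/C=C2\CCC/C(=C\c3ccccc3[N+](=O)[O-])C2=O)cc1` — in an ADME assay on HPLF cells (Homo sapiens) for cytotoxicity, with a stated time of 24 h (on this read-out higher numbers stand for lower toxicity in this test and lower numbers for higher toxicity in this test), compound 1 gives > 400000 nM, which is a limit of the assay.
compound 2 `Cc1ccc(/C=C2\CCC/C(=C\c3ccccc3[N+](=O)[O-])C2=O)cc1` — in this assay compound 2 gives > 400000 nM, again a limit of the assay.
compound 3 `CN(C)c1ccc(/C=C2\CCC/C(=C\c3ccc([N+](=O)[O-])cc3)C2=O)cc1` — in this assay compound 3 gives > 400000 nM, also a limit of the assay.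

Compound 4 `Cc1ccc(/C=C2\CCC/C(=C\c3ccc([N+](=O)[O-])cc3)C2=O)cc1` remains to be measured in this assay. It differs from compound 3 by methyl in place of dimethylamino on an aromatic carbon. The same change is made from compound 1 to compound 2, (methyl in place of dimethylamino on an aromatic carbon), where the step is a step that the two limits leave unreadable from compound 1 to compound 2. The two cores differ by 4-nitrophenyl in place of 2-nitrophenyl on a double-bonded chain carbon bound to a double-bonded ring carbon, with a step that the two limits leave unreadable from compound 1 to compound 3. All that can be read is the limit of > 400000 nM in this assay, at which 3 of the 3 values shown sit. Because of the limit of > 400000 nM in this assay, at which 3 of the 3 values shown sit, the change is expected to leave compound 4 at the same limit, so the step from compound 3 to compound 4 is estimated as a step that the limit leaves unreadable from compound 3 to compound 4. Compound 4 is therefore expected to give about 500000 nM, most likely reported only as a limit, between 200000 nM and 2000000 nM.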

Compound 4, half-maximal cytotoxic concentration: 348000 nM
Estimate against measurement, compound 4: 1.4-fold (0.16 log units) above; the range from low to high includes it.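

In this assay, methyl in place of dimethylamino on an aromatic carbon gives an at least 1.1-fold lower number from compound 3 to compound 4 (0.06 log units; that floor lies within the scatter). The same change from compound 1 to compound 2 and the change from 2-nitrophenyl to 4-nitrophenyl cannot be read, since both ends of each step are limits of the assay, so the new step has no readable counterpart on the other core. Carrying the change from one core to another can therefore be neither confirmed nor ruled out, because nearly all the values rest on one limit: the limit of > 400000 nM in this assay, at which 3 of the 4 values shown sit.

Open, from the compounds shown here alone, is whether a primary amine or a carboxylic acid at this place on the aromatic ring would give a readable value in this assay on either core. Also open, going by these compounds, is whether a nitrile in place of the nitro group would move the number clear of the scatter.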